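Thiophene in place of fluorophenyl on the piperidine benzyl group

A few compounds are considered here, and "the series" means these few. Any claim that something is new, unique, unknown or untested is made for them only; others in the source may bear on it.

Measured compounds:
compound 1, `COc1cc(N)c(Cl)cc1NC(=O)C1CCN(Cc2ccc(F)cc2)CC1`, 0.6 mg/kg
compound 2, `COc1cc(N)c(Cl)cc1NC(=O)C1CCN(Cc2cccc(C#N)c2)CC1`, > 4 mg/kg
compound 3, `COc1cc(N)c(Cl)cc1NC(=O)C1CCN(C2CCCC2)CC1`, > 10 mg/kg

Among the compounds with values here, in a functional assay on the whole organism for antagonist activity, with Mus musculus as the target (a higher number here means that more compound is needed for the effect, a lower number that less compound is needed), compound 1 gives 0.6 mg/kg, the only plain number among the three values. Compound 2 reached only a limit, > 4 mg/kg. Compound 3 likewise reached only a limit, > 10 mg/kg. Both steps away from compound 1 therefore read as losses: an at least 6.6-fold higher number from compound 1 to compound 2 (0.82 log units; beyond the scatter), and an at least 16-fold higher number from compound 1 to compound 3 (1.22 log units; beyond the scatter). The step between compound 2 and compound 3 cannot be sized, since both values are limits.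

Compound 4, `COc1cc(N)c(Cl)cc1NC(=O)C1CCN(Cc2ccsc2)CC1`, has not yet been measured in this assay. Its change from compound 1 is thiophen-3-yl in place of 4-fluorophenyl on a saturated chain carbon bound to an amine nitrogen in a ring. Within the data shown here, of the measured steps, the one from compound 1 to compound 2 is the closer parallel, since there too an aromatic ring on the same saturated chain carbon was exchanged, and it cost at least a modest amount; the step to compound 3, which removed the aromatic ring altogether, cost more. The new ring in compound 4 keeps an aromatic group on the same carbon, so a smaller shift is expected than either measured loss, most likely an increase in the number that stays near the scatter: a 2.0-fold higher number from compound 1 to compound 4 (0.30 log units; within the scatter). Compound 4 is thus estimated at 1.2 mg/kg, in the range 0.4 mg/kg to 4 mg/kg.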

Compound 4, dose for half-maximal effect: 3.4 mg/kg
For compound 4 the middle estimate is 2.8-fold (0.45 log units) below the measured one; the measured number falls inside the stated range.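

In this assay, the change to a thiophen-3-yl group on a saturated chain carbon bound to an amine nitrogen in a ring gives a 5.7-fold higher number from compound 1 to compound 4 (0.75 log units; beyond the scatter), so this position can lose activity beyond the scatter even when an aromatic ring stays in place and no nitrile is present. The aromatic ring still counts for something, as an at least 2.9-fold lower number from compound 3 to compound 4 (0.46 log units; beyond the scatter) favours the (thiophen-3-yl)methyl group over cyclopentyl on the amine nitrogen, whereas an at least 1.1-fold lower number from compound 2 to compound 4 (0.07 log units; that floor lies within the scatter) does not separate thiophen-3-yl from 3-cyanophenyl. The values of compound 2 and compound 3 behind these two steps are limits and not numbers.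

The change from 4-fluorophenyl to thiophen-3-yl replaces the fluorine and the six-membered ring at once, so the compounds shown do not tell which of the two accounts for the loss. Also open, as far as these compounds go, is how a plain phenyl, a thiophen-2-yl or a pyridine ring on the same carbon would compare with compound 1 and compound 4.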